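Acyl variation on the shared core: cytotoxicity notes

This account rests on a few compounds, and the source may have more. Where it says the series, first, only, none or still open, it means among the compounds named here.

Compound 1 `COc1cc(C(=O)C2Sc3nnc(-c4cc(OC)c(OC)c(OC)c4)n3NC2c2ccco2)cc(OC)c1OC` in a functional assay on MCF7 cells (Homo sapiens) for cytotoxicity, read by MTT assay, with a stated time of 48 h (on this read-out higher numbers stand for weaker inhibition and lower numbers for stronger inhibition), gives > 100000 nM, a limit of the assay.
Compound 2 `COc1cc(-c2nnc3n2NC(c2ccco2)C(C(=O)c2ccc(Br)cc2)S3)cc(OC)c1OC` in this assay gives > 100000 nM, a limit of the assay.
Compound 3 `COc1cc(-c2nnc3n2NC(c2ccco2)C(C(=O)C2CC2)S3)cc(OC)c1OC` in this assay gives > 100000 nM, a limit of the assay.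

Compound 3 therefore stands only at a limit, as do the other two measured compounds. The steps a step that the two limits leave unreadable from compound 1 to compound 2, a step that the two limits leave unreadable from compound 1 to compound 3 and a step that the two limits leave unreadable from compound 2 to compound 3 have no readable size because every value sits at the limit of > 100000 nM in this assay, at which 3 of the 3 values shown sit. Compound 4 `COc1cc(-c2nnc3n2NC(c2ccco2)C(C(=O)c2ccc(O)cc2)S3)cc(OC)c1OC` differs from compound 3 by 4-hydroxyphenyl in place of cyclopropyl on a carbonyl carbon. The measured steps on the carbonyl carbon, all unreadable, give no direction for this change, so compound 4 is expected to remain at the same limit, with a number no higher from compound 3 to compound 4 (the limit leaves the size open) expected in this assay. The estimate for compound 4 is 100000 nM, expected between 30000 nM and 300000 nM.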

Compound 4, half-maximal inhibitory concentration: 88900 nM
Estimate against measurement, compound 4: 1.1-fold (0.05 log units) above, within the range that was stated.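

In this assay, for the compounds shown here, compound 4 gives 88900 nM, the only value at this carbonyl carbon that is a number and not a limit of the assay. 4-Hydroxyphenyl in place of cyclopropyl gives an at least 1.1-fold lower number from compound 3 to compound 4 (0.05 log units; that floor lies within the scatter), hydroxy in place of bromo gives an at least 1.1-fold lower number from compound 2 to compound 4 (0.05 log units; that floor lies within the scatter), and 4-hydroxyphenyl in place of 3,4,5-trimethoxyphenyl gives an at least 1.1-fold lower number from compound 1 to compound 4 (0.05 log units; that floor lies within the scatter). These are floors only, and the steps among the other compounds cannot be read, because their values stand at a limit: the limit of > 100000 nM in this assay, at which 3 of the 4 values shown sit.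

On these data alone, whether the hydroxy group itself matters stays open. So does the effect of an amine or a carboxylic acid on the phenyl ring at this carbonyl carbon.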